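A few compounds are considered here, and "the series" means these few. Any claim that something is new, unique, unknown or untested is made for them only; others in the source may bear on it.

Measured in a functional assay on HL-60 cells (Homo sapiens) for antiproliferative activity, with a stated time of 24 h; on this read-out higher numbers stand for weaker inhibition and lower numbers for stronger inhibition:

- compound 1 `NC(=O)c1c(NC(=O)c2ccccc2Cl)sc2c1CCN(Cc1ccc(Cl)cc1Cl)C2`: 8010 nM
- compound 2 `NC(=O)c1c(NC(=O)c2ccccc2Cl)sc2c1CCN(C(=S)Nc1ccccc1)C2`: 5940 nM
- compound 3 `NC(=O)c1c(NC(=O)c2ccccc2Cl)sc2c1CCN(C(=S)Nc1ccccc1F)C2`: 4970 nM

Compound 3 holds the lowest number of the three, but its steps to the other two, a 1.2-fold lower number from compound 2 to compound 3 (0.08 log units; within the scatter) and a 1.6-fold lower number from compound 1 to compound 3 (0.21 log units; within the scatter), both fall within the scatter, so no ranking among the three can be drawn from these numbers.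

Compound 4 `NC(=O)c1c(NC(=O)c2ccccc2Cl)sc2c1CCN(C(=O)Nc1c(Cl)cccc1Cl)C2` differs from compound 3 by a group of 11 heavy atoms (7 carbon, 1 nitrogen, 1 oxygen, 2 chlorine; one six-membered aromatic ring of carbon only) in place of a group of 10 heavy atoms (7 carbon, 1 nitrogen, 1 fluorine, 1 sulfur; one six-membered aromatic ring of carbon only), on an amine nitrogen in a ring. Every measured step in the series bears on this position, since each exchanges or alters the group on that same ring amine nitrogen: a 1.3-fold lower number from compound 1 to compound 2 (0.13 log units; within the scatter), a 1.6-fold lower number from compound 1 to compound 3 (0.21 log units; within the scatter) and a 1.2-fold lower number from compound 2 to compound 3 (0.08 log units; within the scatter). None of them moved the number beyond the scatter, whether the group carried chlorines, a thiocarbonyl or a fluoro. For compound 4 the expectation is therefore no step beyond the scatter, a 1.1-fold higher number from compound 3 to compound 4 (0.04 log units; within the scatter). Compound 4 is estimated at 5500 nM in this assay, with a range of 2200 nM to 14000 nM.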

Compound 4, half-maximal inhibitory concentration: 17700 nM
For compound 4 the middle estimate is 3.2-fold (0.51 log units) below the measured one; the whole stated range lies below it.
By their numbers in this assay, from the lowest: compounds 3, 2 and 1 (each within the scatter of the next); then compound 4.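

Among the compounds shown here, at the group on the ring amine nitrogen, (2,6-dichlorophenyl)carbamoyl is the first exchange in this assay to move the number beyond the scatter, and it does so against all three earlier groups (a 3.6-fold higher number from compound 3 to compound 4 (0.55 log units; beyond the scatter)) (a 3.0-fold higher number from compound 2 to compound 4 (0.47 log units; beyond the scatter)) (a 2.2-fold higher number from compound 1 to compound 4 (0.34 log units; beyond the scatter)). This position therefore does respond to the group it carries, and all three steps run towards weaker inhibition. The change from compound 3 swaps thiocarbonyl for carbonyl and fluoro for two chlorines at once, and nothing at hand accounts for the rise.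

Which of these exchanges carries the rise remains open, and a plain phenylcarbamoyl group on the same nitrogen would separate them. Also open, as far as these compounds go, is how a morpholine, a carboxylic acid or a longer alkyl chain at this position would compare.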